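Chloro in place of methyl on the shared core

A few compounds are considered here, and "the series" means these few. Any claim that something is new, unique, unknown or untested is made for them only; others in the source may bear on it.

- compound 1 `COc1ccc(C2CC(Nc3nc4ccc(C)cc4s3)=NN2C(C)=O)cc1`: 37.3 umol/kg
- compound 2 `CC(=O)N1N=C(Nc2nc3ccc(C)cc3s2)CC1c1ccc(O)cc1`: 50.2 umol/kg
- compound 3 `COc1ccc(C2CC(Nc3nc4ccc(Cl)cc4s3)=NN2C(C)=O)cc1`: not yet measured

In a functional assay on the whole organism (Hindlimb, strain albino) with Mus musculus as the target, in the maximal electroshock model, with a stated time of 0.5 h (on this read-out higher numbers stand for an effect only at larger amounts of compound and lower numbers for an effect already at smaller amounts), compound 1 gives 37.3 umol/kg and compound 2 gives 50.2 umol/kg. Among the measured compounds shown here, these two values lie within the scatter of each other, so compound 1 cannot be separated from its only measured neighbour.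

Compound 3 keeps the core of compound 1 and alters one group: chloro in place of methyl on an aromatic carbon. Put simply, chloro takes the place of methyl on an aromatic carbon of the six-membered ring of carbon only.

For the measured compounds named here, the single measured step, a 1.3-fold higher number from compound 1 to compound 2 (0.13 log units; within the scatter), is a different change: hydrogen in place of methyl on an oxygen on an aromatic ring. It stays within the scatter, but it bears on the new change only indirectly. Going by the values given here, no measured pair shows chloro in place of methyl, so the direction remains open and no shift beyond the scatter is expected in this assay. The expected change is a 1.1-fold lower number from compound 1 to compound 3 (0.05 log units; within the scatter). For compound 3 the estimate is 33 umol/kg, with an expected range from 12 umol/kg to 90 umol/kg.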

Compound 3, dose for half-maximal effect: 93.3 umol/kg
For compound 3 the middle estimate is 2.8-fold (0.45 log units) below the measured one; measured number outside the range, above it.
By their numbers in this assay, from the lowest: compounds 1, 2 and 3 (each within the scatter of the next, the first and the last beyond it).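

In this assay, the exchange at this position gives a 2.5-fold higher number from compound 1 to compound 3 (0.40 log units; beyond the scatter), the first listed step that lies beyond the scatter, although modest in size. The earlier step, a 1.3-fold higher number from compound 1 to compound 2 (0.13 log units; within the scatter), changed a different place and stayed within the scatter, so this aromatic carbon, on the six-membered ring of carbon only within the fused system, is the one place shown so far where a single change separates two compounds: with chloro instead of methyl, a larger amount of compound is needed, even though one heavy atom replaces one heavy atom and the counted hydrogen-bond donors, acceptors and charge stay the same. Nothing available explains why this exchange moves the number.

On these data alone, with only methyl and chloro at this position, no trend can be drawn, and how fluoro, methoxy or an amine on the same aromatic carbon would read remains open. Also open, as far as these compounds go, is whether chloro in place of methyl would give a step of similar size on the core of compound 2, which carries hydrogen in place of the methyl on the oxygen.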